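Sulfonyl group change from compound 2 to compound 3

The source may hold more compounds than are shown below. What is called first, only, known or untested is meant among the compounds shown, and "the series" means these compounds.

Of the compounds shown here, two have been measured so far in a functional assay on A2780 cells (Homo sapiens) for cytotoxicity, read by sulforhodamine B assay, with a stated time of 72 h; a higher number here means a weaker inhibitor, a lower number a stronger inhibitor (values below).
- compound 1 `O=C(NCc1ccc(S(=O)(=O)C2CCCOC2)cc1)N1Cc2ccncc2C1` gives 32 nM as its half-maximal inhibitory concentration
- compound 2 `O=C(NCc1ccc(S(=O)(=O)N2CCC(O)CC2)cc1)N1Cc2ccncc2C1` gives 98 nM as its half-maximal inhibitory concentration

Compound 2 holds the higher of the two numbers, so it is the weaker inhibitor of the pair, and the gap to compound 1 lies beyond the scatter. Compound 3 `O=C(NCc1ccc(S(=O)(=O)N2CC3(CCOCC3)C2)cc1)N1Cc2ccncc2C1` is not yet measured and differs from compound 2 by a single change (a group of 9 heavy atoms (7 carbon, 1 nitrogen, 1 oxygen; one four-membered non-aromatic ring with 1 hetero atom, one six-membered non-aromatic ring with 1 hetero atom) in place of a group of 7 heavy atoms (5 carbon, 1 nitrogen, 1 oxygen; one six-membered non-aromatic ring with 1 hetero atom), on a sulfonyl sulfur). Among the compounds with values here, only one measured step bears on this change (a 3.1-fold higher number from compound 1 to compound 2 (0.49 log units; beyond the scatter)). That step is modest, sits on the same sulfonyl sulfur, and has the 4-hydroxypiperidin-1-yl on its higher side. The group entering in compound 3 has no measurement of its own, so this is thin evidence. A modest move towards a lower number is expected in this assay as 4-hydroxypiperidin-1-yl leaves. The expected step is a 2.2-fold lower number from compound 2 to compound 3 (0.34 log units; beyond the scatter) and may not clear the scatter. For compound 3 the estimate is 45 nM (expected range 12 nM to 160 nM).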

Compound 3, half-maximal inhibitory concentration: 10 nM
Compound 3: middle estimate off by 4.5-fold (0.65 log units), on the high side, and the stated range ends above it.
By their numbers in this assay, from the lowest: compound 3; then compound 1; then compound 2.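

Notes on the sulfonyl sulfur position in this assay: the group carrying a four-membered and a six-membered non-aromatic ring gives a 9.8-fold lower number from compound 2 to compound 3 (0.99 log units; beyond the scatter) and, against the oxan-3-yl group, gives a 3.2-fold lower number from compound 1 to compound 3 (0.51 log units; beyond the scatter) as well. The earlier pair alone placed the nitrogen-containing 4-hydroxypiperidin-1-yl on the higher side of oxan-3-yl, but compound 3 also has a nitrogen in this group and holds the lowest number of the three, so a nitrogen in the group does not by itself go with a higher number here, and the position spans a wider range than the first step showed. No measurement on hand accounts for this result.

The change from compound 2 to compound 3 removes the hydroxyl and alters the ring system in a single step, so these compounds cannot separate the two changes. On these data alone, a morpholin-4-yl or 4-methoxypiperidin-1-yl group on the sulfonyl sulfur would bear on the hydroxyl question, while the contribution of the four-membered ring, and whether a basic amine on the same group is tolerated, remain open.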